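Aryl substituent series on the shared core: methyl to methoxy

A few compounds are considered here, and "the series" means these few. Any claim that something is new, unique, unknown or untested is made for them only; others in the source may bear on it.

Values in an assay on cell membranes for displacement of a labelled ligand from Neuronal acetylcholine receptor; alpha4/beta2 (Rattus norvegicus); a higher number here means a weaker inhibitor, a lower number a stronger inhibitor:
Compound 1 `FC(F)(F)c1ccc(Nc2ccc(N3CC4CC(C3)N4)cn2)cc1`: 0.569 nM
Compound 2 `Oc1ccc(Nc2ccc(N3CC4CC(C3)N4)cn2)cc1`: 7.1 nM
Compound 3 `Cc1ccc(Nc2ccc(N3CC4CC(C3)N4)cn2)cc1`: 52.1 nM

Compound 3 gives the highest number of the three in this assay. The step of a 7.3-fold higher number from compound 2 to compound 3 (0.87 log units; beyond the scatter) lies beyond the scatter, and the step of a 92-fold higher number from compound 1 to compound 3 (1.96 log units; beyond the scatter) more so. Compound 1 stands lowest, separated from compound 2 by the step of a 12-fold higher number from compound 1 to compound 2 (1.10 log units; beyond the scatter).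

Compound 4 `COc1ccc(Nc2ccc(N3CC4CC(C3)N4)cn2)cc1` is not yet measured. It differs from compound 3 in one place: methoxy in place of methyl on an aromatic carbon. Of the measured steps only a 7.3-fold higher number from compound 2 to compound 3 (0.87 log units; beyond the scatter) bears directly on this change: that step replaced hydroxy with methyl, and the change to compound 4 reverses part of that exchange, putting a group counted with one hydrogen-bond acceptor and no donor in place of methyl. A modest move toward a lower number in this assay is therefore expected, likely not the full reverse of that step. For compound 4 the expected step is a 3.5-fold lower number from compound 3 to compound 4 (0.54 log units; beyond the scatter), and the estimate is 15 nM with a range of 4 nM to 55 nM.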

Compound 4, inhibition constant: 7.3 nM
Estimate against measurement, compound 4: 2.1-fold (0.31 log units) above; the range from low to high includes it.
By their numbers in this assay, from the lowest: compound 1; then compounds 2 and 4 (each within the scatter of the next); then compound 3.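

In this assay the methyl added on the oxygen gives a 1.0-fold higher number from compound 2 to compound 4 (0.01 log units; within the scatter) and so hydroxy and methoxy cannot be told apart at this place, which means the hydrogen on that oxygen is not needed to reach this level. Going the other way, a 7.1-fold lower number from compound 3 to compound 4 (0.85 log units; beyond the scatter) is close in size to a 7.3-fold higher number from compound 2 to compound 3 (0.87 log units; beyond the scatter) and so, among these compounds, both groups with an oxygen on the aromatic carbon stand apart from methyl. Methoxy still does not reach trifluoromethyl, with a 13-fold higher number from compound 1 to compound 4 (1.11 log units; beyond the scatter) as the remaining gap in this series.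

From the compounds shown here alone, whether a longer chain on the oxygen, such as ethoxy, would stay level with compound 4 remains open. So does the place of an amine, a carboxylic acid or a chlorine atom on this aromatic carbon. No measurement at hand accounts for these steps.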